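The source may report more compounds than this note shows. Statements on the series, on what has been measured and on what is new or still open speak of the compounds shown alone.

In a functional assay on A2780 cells (Homo sapiens) for inhibition (on this read-out lower numbers stand for stronger inhibition and higher numbers for weaker inhibition), compound 1 `CC(C(=O)Nc1cc(C2CC2)[nH]n1)c1ccc(N2C(=O)CCC2C)cc1` gives 6400 nM and sits within the scatter of compound 2 `CC(C(=O)Nc1cc(C2CC2)[nH]n1)c1ccc(N2Cc3ccccc3C2=O)cc1` at 4750 nM in this small set, while compound 3 `CC(C(=O)Nc1cc(C2CC2)[nH]n1)c1ccc(N2C(=O)CCC2c2ccccc2)cc1` reads 15300 nM and lies beyond the scatter from compound 1. Compound 4 `CC(C(=O)Nc1cc(C2CC2)[nH]n1)c1ccc(-n2cnnc2O)cc1` is still unmeasured and carries this change from compound 1: a group of 6 heavy atoms (2 carbon, 3 nitrogen, 1 oxygen; one five-membered aromatic ring with 3 hetero atoms) in place of a group of 7 heavy atoms (5 carbon, 1 nitrogen, 1 oxygen; one five-membered non-aromatic ring with 1 hetero atom), on an aromatic carbon. Among the compounds with values here, only one measured step bears on it, and only indirectly: a 2.4-fold higher number from compound 1 to compound 3 (0.38 log units; beyond the scatter) is modest and alters a substituent on the ring that leaves here. Within the data shown here, no measured step covers replacing that whole ring, so in this assay only a small move towards a higher number is expected, possibly none beyond the scatter. The estimated step is a 1.3-fold higher number from compound 1 to compound 4 (0.10 log units; within the scatter) overall. Compound 4 is expected at 8000 nM with an estimated range from 2500 nM to 25000 nM for this measurement.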

Compound 4, half-maximal inhibitory concentration: 8390 nM
For compound 4 the middle estimate is 1.0-fold (0.02 log units) below the measured one, and the stated range covers the measured number.
By their numbers in this assay, from the lowest: compounds 2, 1, 4 and 3 (each within the scatter of the next, the first and the last beyond it).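

Replacing the whole five-membered non-aromatic ring with a five-membered aromatic ring with 3 hetero atoms gives a 1.3-fold higher number from compound 1 to compound 4 (0.12 log units; within the scatter) in this assay. Within the data shown here, the only earlier step altered a substituent on the ring, whereas this one shows that the ring itself on this aromatic carbon can be exchanged, hydrogen-bond donor included, with a step that stays within the scatter. Nothing measured here accounts for this result. Still open, as far as these compounds go, is whether a simple amine or an open-chain amide on this carbon, with no ring at all, would read alike.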